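The source may report more compounds than this note shows. Statements on the series, on what has been measured and on what is new or still open speak of the compounds shown alone.

Compound 1 `Nc1ccc(C2=NNC(=O)CC2)cc1`: 46.4 ug/mL
Compound 2 `CC1CC(c2ccc(N)cc2)=NNC1=O`: 43.8 ug/mL

In a functional assay for inhibition, with Homo sapiens as the target (a lower number here means that less compound is needed, a higher number that more compound is needed for the effect), compound 2 gives 43.8 ug/mL, which lies within the scatter of the value for compound 1. Within the data shown here, the only measured step is a 1.1-fold lower number from compound 1 to compound 2 (0.03 log units; within the scatter), and it adds a methyl group to the core of compound 1.

Compound 3 `CC1CC(c2ccc(NC(=O)CCl)cc2)=NNC1=O` is changed elsewhere: (chloromethyl)carbonyl in place of hydrogen on a nitrogen on an aromatic ring. Here, (chloromethyl)carbonyl takes the place of hydrogen on a nitrogen on an aromatic ring, so amino becomes ((chloromethyl)carbonyl)amino. The measured step concerns a different place and a much smaller group, so it gives little guidance on size or direction. Among the measured compounds shown here, no measured compound carries anything on this nitrogen. The estimate is therefore a cautious judgement with a wide range, leaning towards a lower number. The expected change is a 2.2-fold lower number from compound 2 to compound 3 (0.34 log units; beyond the scatter). For compound 3, the estimated value is 20 ug/mL, with an expected range of 5 ug/mL to 80 ug/mL.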

Compound 3, half-maximal effective concentration: 21.9 ug/mL
Compound 3: the middle estimate sits 1.1-fold (0.04 log units) below what was measured, and the stated range covers the measured number.
By their numbers in this assay, from the lowest: compounds 3, 2 and 1 (each within the scatter of the next, the first and the last beyond it).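

Replacing hydrogen with (chloromethyl)carbonyl on the nitrogen on an aromatic ring, which turns amino into ((chloromethyl)carbonyl)amino, gives a 2.0-fold lower number from compound 2 to compound 3 (0.30 log units; within the scatter) in this assay. Among these compounds, this is the first reading for any group on this nitrogen, as the earlier compounds carry only the free amino group there. It shows that, in this pair, the nitrogen need not stay a free amino group for the value to remain within the scatter, but nothing available explains this result.

Going by these compounds, it remains open whether the chlorine or the carbonyl matters here: an acetyl group, which has no chlorine, or a single methyl on the same nitrogen would help separate the two. On these data alone, it is also open whether a longer chain, such as a butanoyl group, or a benzoyl group would give a similar reading in this assay at this position.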